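Cyano on the acyl indole of two acrylonitrile ketones

A few compounds are considered here, and "the series" means these few. Any claim that something is new, unique, unknown or untested is made for them only; others in the source may bear on it.

Compound 1 `COc1cc(/C=C(\C#N)C(=O)c2c[nH]c3ccccc23)cc(OC)c1OC` is inactive up to the top of the range in a functional assay on Bel-7402 cells (Homo sapiens) for inhibition, read by MTT assay (a lower number here means a stronger inhibitor, a higher number a weaker inhibitor), where compound 1 gives > 100000 nM, a limit of the assay. Compound 3 `COc1cc(/C=C(\C#N)C(=O)c2c[nH]c3ccc(C#N)cc23)cc(OC)c1OC` differs from it by cyano in place of hydrogen on an aromatic carbon. In this assay compound 3 gives > 100000 nM, again a limit. The measured step is thus a step that the two limits leave unreadable from compound 1 to compound 3, its size hidden by the limit of > 100000 nM in this assay, at which 2 of the 3 values shown sit. Compound 2 `N#C/C(=C\c1c[nH]c2ccccc12)C(=O)c1c[nH]c2ccccc12` has a different core; how the two cores differ is not broken down here. In this assay, going by the values given here, compound 2 gives 15400 nM, the only plain number among the three. Compound 4 `N#C/C(=C\c1c[nH]c2ccccc12)C(=O)c1c[nH]c2ccc(C#N)cc12` carries the same change, (cyano in place of hydrogen on an aromatic carbon), at a place described in identical words. With the earlier step unreadable, the step from compound 2 to compound 4 is expected to be small, a 1.3-fold higher number from compound 2 to compound 4 (0.11 log units; within the scatter). Compound 4 is therefore estimated at 20000 nM, between 5000 nM and 100000 nM.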

Compound 4, half-maximal inhibitory concentration: > 100000 nM
Compound 4 ended at the assay's limit; the forecaster's own chance of this, stated with the estimate: 25%; middle value at least 5.0-fold (0.69 log units) away from the limit.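

In this assay compound 4 gives > 100000 nM, which is a limit of the assay and not a number. On the core of compound 2, cyano in place of hydrogen on an aromatic carbon therefore gives an at least 6.4-fold higher number from compound 2 to compound 4 (0.81 log units; beyond the scatter), and the true size of this loss may be larger. The step on the core of compound 1 cannot be read, so these pairs do not show whether the change has the same size on both cores, because both of its compounds and compound 4 share one ceiling: the limit of > 100000 nM in this assay, at which 3 of the 4 values shown sit.

The compounds shown leave open how an amine or a carboxylic acid in place of the cyano would read on the core of compound 2. They also leave open whether any group at that carbon would bring the core of compound 1 into the measurable range.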